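The source may report more compounds than this note shows. Statements on the series, on what has been measured and on what is new or still open speak of the compounds shown alone.

Compound 1, with the structure `CSc1ccc(/C=C(\C(=O)c2ccc(Cl)cc2)S(=O)(=O)Cc2ccc(C)cc2)cc1`, and compound 2, with the structure `CSc1ccc(/C=C(\C(=O)c2ccc(Br)cc2)S(=O)(=O)Cc2ccc(C)cc2)cc1`, share one core and differ only at one aromatic carbon. In a functional assay on DU-145 cells (Homo sapiens) for inhibition, read by trypan blue exclusion, with a stated time of 96 h (a lower number here means a stronger inhibitor of growth, a higher number a weaker inhibitor of growth), compound 1 gives 10000 nM, and compound 2 gives 10000 nM. The single measured step, no change at the digits printed from compound 1 to compound 2 (within the scatter), exchanges bromo for chloro on an aromatic carbon, so on the numbers shown compound 1 stands level with compound 2.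

Compound 3, with the structure `Cc1ccc(CS(=O)(=O)/C(=C/c2c(O)cc(O)cc2O)C(=O)c2ccc(Cl)cc2)cc1`, differs from compound 1 in a different way: 2,4,6-trihydroxyphenyl in place of 4-(methylsulfanyl)phenyl on a double-bonded chain carbon bound to a double-bonded chain carbon. Going by the values given here, no measured step exchanges this ring, so the one step that exists does not bear on this change and gives no direction for it. For that reason the expected step of a 1.3-fold lower number from compound 1 to compound 3 (0.10 log units; within the scatter) is taken as small, with a wide range around it. Compound 3 is therefore estimated to give about 8000 nM, between 2000 nM and 30000 nM, in this assay.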

Compound 3, concentration for 50% growth inhibition: > 100000 nM
Compound 3: a limit, no number; the forecaster's own chance of this, stated with the estimate: 25%; at least 12-fold (1.09 log units) between middle value and limit.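

The reading for compound 3 is a limit of the assay, not a number: the limit of > 100000 nM in this assay, at which 1 of the 3 values shown sits. The exchange of bromo for chloro had shown no response at the digits printed, but that change lay elsewhere on the shared core and said nothing about this place. In this assay, 2,4,6-trihydroxyphenyl in place of 4-(methylsulfanyl)phenyl on a double-bonded chain carbon bound to a double-bonded chain carbon gives an at least 10-fold higher number from compound 1 to compound 3 (1.00 log units; beyond the scatter), so the group at this place clearly matters to growth inhibition, and this replacement goes the wrong way.

With one replacement shown, the compounds cannot tell whether all the hydroxy groups together or only some of them go with this loss. On these data alone, it also remains open whether a single methoxy group or an amine on this ring would keep compound 3 weak or stay level with compound 1.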